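This account rests on a few compounds, and the source may have more. Where it says the series, first, only, none or still open, it means among the compounds named here.

The measured compounds and their numbers:
Compound 1, `COc1cc2c(cc1OC)C(CC(=O)O)CC2`, in a functional assay on the whole organism (strain Wistar) for inhibition, with Rattus norvegicus as the target, read by paw edema, with a stated time of 6 h, at a dose of 100 mg/kg (on this read-out higher numbers stand for more inhibition at the one dose given (going by the name of the read-out) and lower numbers for less inhibition), gives 20.4%.
Compound 2, `COc1cc2c(cc1OC)C(CC(=O)Nc1cccc(Cl)c1)CC2`, gives 38.9%.
Compound 3, `COc1cc2c(cc1OC)C(CC(=O)Nc1ccc(C)cc1)CC2`, gives 37%.

Compound 3 stands second of the three numbers. Its nearest neighbour is compound 2, separated by a gap within the scatter, a number 1.9 percentage points lower from compound 2 to compound 3 (within the scatter), while its distance from compound 1 is beyond the scatter, as the step of a number 16.6 percentage points higher from compound 1 to compound 3 (beyond the scatter) shows. Compound 4 is `COc1cc2c(cc1OC)C(CC(=O)Nc1cccnc1)CC2`. It differs from compound 3 in one place: pyridin-3-yl in place of 4-methylphenyl on an amide-type nitrogen. Cut one bond further out, the change reads (4-methylphenyl)amino to (pyridin-3-yl)amino. Within the data shown here, only one measured step concerns the group on the amide-type nitrogen, a number 1.9 percentage points lower from compound 2 to compound 3 (within the scatter), and that exchange left the number unchanged within the scatter. The steps of a number 18.5 percentage points higher from compound 1 to compound 2 (beyond the scatter) and a number 16.6 percentage points higher from compound 1 to compound 3 (beyond the scatter) concern the replacement of hydroxy on a carbonyl carbon and so do not speak to the present change. Compound 4 is therefore expected to give a number close to that of compound 3, with the step of a number 4 percentage points lower from compound 3 to compound 4 (within the scatter) expected to stay within the scatter. The estimate for compound 4 in this assay is 33%, within a range from 22% to 44%.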

Compound 4, a percentage reported as inhibition, in the whole organism at one dose (the size of the read-out at that dose, not a potency): 35.2%
For compound 4 the middle estimate is 2.2 percentage points below the measured one; measured number inside the range.
By their numbers in this assay, from the lowest: compound 1; then compounds 4, 3 and 2 (each within the scatter of the next).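

In this assay, among these compounds, the change to pyridin-3-yl brings a ring with a hetero atom onto the amide-type nitrogen for the first time, and it gives a number 1.8 percentage points lower from compound 3 to compound 4 (within the scatter) against 4-methylphenyl and a number 3.7 percentage points lower from compound 2 to compound 4 (within the scatter) against 3-chlorophenyl. The hetero atom and the added hydrogen-bond acceptor therefore leave no readable mark on the number at this position, and the gain over the hydroxy of compound 1 is kept, as a number 14.8 percentage points higher from compound 1 to compound 4 (beyond the scatter) shows. No evidence at hand explains why these three rings read alike.

Whether an aromatic ring on this nitrogen is needed at all stays open, as the compounds shown hold no benzyl or cyclohexyl group there and no plain primary amide. They also leave open how far the number moves with a different dose or time.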